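Chloro on the pyridylmethyl arm: cytotoxicity notes

The source may report more compounds than this note shows. Statements on the series, on what has been measured and on what is new or still open speak of the compounds shown alone.

compound 1 `CC(=O)N1CCC(C(=O)N(CCCN2CCC(CNc3cc(C)ccn3)CC2)c2ccc(C)c(Cl)c2)CC1` — 17900 nM
compound 2 `CC(=O)N1CCC(C(=O)N(CCCN2CCN(Cc3cccnc3)CC2)c2ccc(C)c(Cl)c2)CC1` — > 56700 nM
compound 3 `CC(=O)N1CCC(C(=O)N(CCCN2CCN(c3ccccn3)CC2)c2ccc(C)c(Cl)c2)CC1` — > 58300 nM

Among the measured compounds shown here, in an ADME assay (Homo sapiens) for cytotoxicity (on this read-out lower numbers stand for higher toxicity in this test and higher numbers for lower toxicity in this test), compound 1 gives 17900 nM, the only full number in the set. For compound 2 only a limit of this assay is recorded, > 56700 nM. For compound 3 the same holds, a limit at > 58300 nM. For the measured compounds named here, the one single-point step among the measured compounds, a step that the two limits leave unreadable from compound 2 to compound 3, cannot be sized because the limit of > 56700 nM in this assay, at which 1 of the 3 values shown sits, and the limit of > 58300 nM in this assay, at which 1 of the 3 values shown sits, both sit at the end of the measurable range. Compound 2 therefore stands at the low-toxicity end of what this assay reports, with no number to anchor it.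

Compound 4 `CC(=O)N1CCC(C(=O)N(CCCN2CCN(Cc3ccc(Cl)nc3)CC2)c2ccc(C)c(Cl)c2)CC1` differs from compound 2 by chloro in place of hydrogen on an aromatic carbon. Going by the values given here, no measured step carries this change, and the only step is unreadable, so the expectation rests on where compound 2 stands. The step of an at least 1.1-fold lower number from compound 2 to compound 4 (0.05 log units; that floor lies within the scatter) is expected to be none beyond the scatter. Compound 4 is thus expected near 50000 nM, within 20000 nM to 90000 nM, most likely reported again as a limit.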

Compound 4, half-maximal cytotoxic concentration: > 53100 nM
Compound 4: a limit, no number; the forecaster's own chance of this, stated with the estimate: 60%; middle value at least 1.0-fold (0.02 log units) away from the limit.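

In this assay compound 4 gives only a limit, > 53100 nM. Among the compounds shown here, compound 2, compound 3 and compound 4 all carry limits, so no step among them can be read. From the compounds shown here alone, whether chloro in place of hydrogen on an aromatic carbon changes cytotoxicity at all remains open.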